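A few compounds are considered here, and "the series" means these few. Any claim that something is new, unique, unknown or untested is made for them only; others in the source may bear on it.

Within the data shown here, compound 2 `O=C(/C=C\Nc1ccc(Cl)cc1)c1cn(-c2ccccc2)nc1-c1ccc(Cl)cc1` gives 13100 nM in a functional assay on U-87MG ATCC cells (Homo sapiens) for antiproliferative activity, read by MTT assay, with a stated time of 48 h (a higher number here means a weaker inhibitor, a lower number a stronger inhibitor), and stands lowest of the two numbers measured so far; the nearest is compound 1 `O=C(/C=C\Nc1ccc(F)cc1)c1cn(-c2ccccc2)nc1-c1ccc(Cl)cc1`, which in this assay gives 17900 nM, a gap within the scatter. Among the measured compounds shown here, the only step measured so far, a 1.4-fold lower number from compound 1 to compound 2 (0.14 log units; within the scatter), exchanges one halogen for another on the same aromatic carbon and leaves the number where it was. Compound 3 `O=C(/C=C\Nc1ccc(O)cc1)c1cn(-c2ccccc2)nc1-c1ccc(Cl)cc1` differs from compound 2 by hydroxy in place of chloro on an aromatic carbon. For the measured compounds named here, no measured step exchanges a halogen for a hydroxy group, so the one step available bears on it only in showing that a change on this aromatic carbon passed without movement beyond the scatter. The expectation for compound 3 in this assay is therefore a step of a 1.1-fold higher number from compound 2 to compound 3 (0.06 log units; within the scatter), with no direction beyond the scatter, and the range is set wide because the hydroxy group is not covered by any measured step. Compound 3 is estimated at 15000 nM, expected to fall between 6000 nM and 40000 nM.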

Compound 3, half-maximal inhibitory concentration: 1500 nM
Estimate against measurement, compound 3: 10-fold (1.00 log units) above; the measured number lies below the stated range.
By their numbers in this assay, from the lowest: compound 3; then compounds 2 and 1 (each within the scatter of the next).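

In this assay the aromatic carbon that looked indifferent while it carried only halogens now proves responsive to the group placed on it: hydroxy in place of chloro gives an 8.7-fold lower number from compound 2 to compound 3 (0.94 log units; beyond the scatter) and hydroxy in place of fluoro gives a 12-fold lower number from compound 1 to compound 3 (1.08 log units; beyond the scatter) in a series where the halogen exchange alone stayed within the scatter. Compound 1 and compound 2 therefore stay together and compound 3 stands apart from both, so on this carbon the identity of the halogen has not moved the number beyond the scatter, whereas leaving the halogens for hydroxy has; the exchange keeps the heavy-atom count of the group unchanged and adds one hydrogen-bond donor and one hydrogen-bond acceptor. Nothing at hand accounts for the size of this step.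

On these data alone, it remains open whether methoxy or an amine on this carbon would follow hydroxy or stay with the halogens, and whether a carboxylic acid there would lower the number further. Also open, as far as these compounds go, is whether hydroxy in place of the chloro of the 4-chlorophenyl group on the core of compound 3 would give any comparable step.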